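The source may hold more compounds than are shown below. What is called first, only, known or untested is meant among the compounds shown, and "the series" means these compounds.

Measured compounds in the series:

- compound 1 `Brc1ccc(-c2cc(COc3ccccc3-c3nc4ccccc4s3)on2)cc1`: 16400 nM
- compound 2 `COc1cc(-c2cc(COc3ccccc3-c3nc4ccccc4s3)on2)cc(OC)c1OC`: 17500 nM
- compound 3 `c1ccc(-n2cc(COc3ccccc3-c3nc4ccccc4s3)nn2)cc1`: 16600 nM

All three were read in a functional assay on COLO 205 cells (Homo sapiens) for cytotoxicity, read by MTT assay, with a stated time of 24 h; a higher number here means a weaker inhibitor, a lower number a stronger inhibitor. Compound 1 gives 16400 nM, the lowest of the three numbers, but the values of compound 2 and compound 3 sit so close to it that the three cannot be put in any order; none of the differences among them goes beyond the usual scatter of this kind of measurement. What the three show is that the shared core carries the result, and that changing the aryl group on the outer ring, or swapping one five-membered heterocycle for another, has left the readout where it was.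

Compound 4 `FC(F)(F)Oc1ccc(-c2cc(COc3ccccc3-c3nc4ccccc4s3)on2)cc1` has not yet been measured in this assay. Relative to compound 1 the change is trifluoromethoxy in place of bromo on an aromatic carbon. Among the measured compounds shown here, nothing among the measured pairs gives a step for this kind of change, and the measured set as a whole shows no sensitivity to what stands on the outer aryl ring. The expectation is therefore a step of a 1.0-fold higher number from compound 1 to compound 4 (0.00 log units; within the scatter), that is, nothing beyond the scatter in either direction. Compound 4 is expected to give about 16500 nM in this assay, within a range from 8000 nM to 34000 nM.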

Compound 4, half-maximal inhibitory concentration: 19900 nM
The estimate for compound 4 lay 1.2-fold (0.08 log units) below the measured number; the measured number falls inside the stated range.
By their numbers in this assay, from the lowest: compounds 1, 3, 2 and 4 (each within the scatter of the next).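

In this assay the exchange of 4-bromophenyl for 4-(trifluoromethoxy)phenyl gives the series its first step that differs in one place, with a 1.2-fold higher number from compound 1 to compound 4 (0.08 log units; within the scatter). Among the compounds shown here, the position, on an aromatic carbon para to a large group, thus accepts trifluoromethoxy with its five heavy atoms and one hydrogen-bond acceptor in place of a single bromine, with no step beyond the scatter; the earlier compounds suggested this insensitivity only through comparisons that differed in more than one place. Nothing on hand bears on why the number holds at this position.

As far as these compounds go, whether an amine, a carboxylic acid or a longer alkoxy chain on the same aromatic carbon would move the number beyond the scatter remains open. Also open, from the compounds shown here alone, is whether the same exchange would read alike on the phenyl group of compound 3, which stands on a different five-membered heterocycle, and whether any change within the shared core itself would shift the readout.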